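The source may report more compounds than this note shows. Statements on the series, on what has been measured and on what is new or still open speak of the compounds shown alone.

In a functional assay on HGC-27 cells (Homo sapiens) for cytotoxicity, read by MTT assay, with a stated time of 48 h (a lower number here means a stronger inhibitor, a higher number a weaker inhibitor), compound 1 `COc1ccc(/C=C/C(=O)/C=C/c2cc3ccccc3nc2Oc2ccccc2)cc1` gives > 10000 nM as a limit, not a number. Compound 2 `COc1ccc(/C=C/C(=O)/C=C/c2cc3ccccc3nc2Oc2ccccc2)cc1OC` gives > 10000 nM as a limit too, so it stands only at that limit and has no number of its own. For the measured compounds named here, compound 3 `COc1cc(OC)c(OC)cc1/C=C/C(=O)/C=C/c1cc2ccccc2nc1Oc1ccccc1` gives 10500 nM as the one measured number so far. The series thus rests largely on the limit of > 10000 nM in this assay, at which 2 of the 3 values shown sit, for now.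

Compound 4 `COc1ccc(/C=C/C(=O)/C=C/c2cc3ccccc3nc2Oc2cccc(Cl)c2)cc1OC` differs from compound 2 by chloro in place of hydrogen on an aromatic carbon in one change: chloro in place of hydrogen on an aromatic carbon, phenoxy to 3-chlorophenoxy. The measured steps on hand are a step that the two limits leave unreadable from compound 1 to compound 2 and a step that the limit leaves unreadable from compound 2 to compound 3 with no size to carry over. Both put methoxy in place of hydrogen, not chloro, so neither gives a size or a direction for this change. No direction is expected, and the estimate stays close to compound 3 at 10500 nM as the anchor. The expected move is an at least 1.1-fold lower number from compound 2 to compound 4 (0.04 log units; that floor lies within the scatter) as estimated here, and the result may again be only a limit. For compound 4 the estimate is 9000 nM with a range of 3000 nM to 25000 nM expected.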

Compound 4, half-maximal inhibitory concentration: > 10000 nM
Compound 4 gave a limit, no number; the forecaster's own chance of this, stated with the estimate: 45%; at least 1.1-fold (0.04 log units) between middle value and limit.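

Compound 4 gives only a limit, as does compound 2, so no step can be read between them in this assay: the limit of > 10000 nM in this assay, at which 3 of the 4 values shown sit. The compounds shown leave open whether phenoxy to 3-chlorophenoxy moves the value in this assay at all, and in which direction.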